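The source may hold more compounds than are shown below. What is called first, only, known or untested is meant among the compounds shown, and "the series" means these compounds.

Working notes on the series. Compound 3, `CCCc1nc(-c2ccccc2)c(CNCCCN2CCN(c3ccc(Cl)cc3)CC2)o1`, gives 63.3% in an assay on HEK293 cells for inhibition of Voltage-dependent T-type calcium channel subunit alpha-1G (Homo sapiens), read by fluorescence, tested at 10 uM (a higher number here means more inhibition at the concentration tested (going by the name of the read-out), a lower number less inhibition), and stands highest of the three numbers in hand. Compound 2, `CCCc1nc(-c2ccccc2)c(CNCCCN2CCN(c3ccccc3)CC2)o1`, gives 43.7% in this assay. Compound 1, `CCCc1nc(-c2ccccc2)c(CNCCCN2CCN(c3cccc(OC)c3)CC2)o1`, gives 36.4% in this assay. The steps between them are a number 7.3 percentage points higher from compound 1 to compound 2 (within the scatter), a number 19.6 percentage points higher from compound 2 to compound 3 (beyond the scatter) and a number 26.9 percentage points higher from compound 1 to compound 3 (beyond the scatter).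

Compound 4, `CCCc1nc(-c2ccccc2)c(CNCCCN2CCN(c3ccc(C)c(C)c3)CC2)o1`, is the next member: 3,4-dimethylphenyl in place of 4-chlorophenyl on an amine nitrogen in a ring. Among the measured compounds shown here, two measured steps bear on this change, since both alter the aromatic ring on the ring nitrogen: a number 19.6 percentage points higher from compound 2 to compound 3 (beyond the scatter) and a number 26.9 percentage points higher from compound 1 to compound 3 (beyond the scatter). For the measured compounds named here, both show that the ring bearing chloro gives the highest number so far, and that removing or replacing that group lowered the number by a modest amount. Going by the values given here, no measured step shows 3,4-dimethylphenyl, so the direction is uncertain; a modest decrease or a step within the scatter is expected, giving a number 11.3 percentage points lower from compound 3 to compound 4 (beyond the scatter). Compound 4 is therefore estimated at 52% in this assay, with a range from 32% to 72%.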

Compound 4, a percentage reported as inhibition, at one concentration (the size of the read-out at that concentration, not a potency): 54.6%
Beside the measured number, compound 4's estimate is 2.6 percentage points below it, within the range that was stated.
By their numbers in this assay, from the lowest: compounds 1 and 2 (each within the scatter of the next); then compounds 4 and 3 (each within the scatter of the next).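

The step of a number 8.7 percentage points lower from compound 3 to compound 4 (within the scatter) shows that in this assay, 3,4-dimethylphenyl on the amine nitrogen in the ring keeps the number within the scatter of 4-chlorophenyl, so a chlorine is not needed on this ring for a number of this size. The steps of a number 10.9 percentage points higher from compound 2 to compound 4 (beyond the scatter) and a number 18.2 percentage points higher from compound 1 to compound 4 (beyond the scatter) place 3,4-dimethylphenyl beyond the scatter of both phenyl and 3-methoxyphenyl, so two substituted rings now stand clear of phenyl, while 3-methoxyphenyl in compound 1 goes against any reading that substitution alone raises the number. Nothing measured here gives a reason for these differences.

Still open, from the compounds shown here alone, is whether a trifluoromethyl, a nitrile or a carboxylic acid on this aromatic ring would hold the number at this level. Also open, going by these compounds, is whether a single methyl would serve as well as the two in compound 4.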